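A few compounds are considered here, and "the series" means these few. Any claim that something is new, unique, unknown or untested is made for them only; others in the source may bear on it.

Working notes on the series. Compound 1 `CCOC(=O)C1=C(Nc2ccccc2)S/C(=C\c2ccc[nH]2)C1=O` carries an unsubstituted anilino group on the shared core; in a functional assay on MCF7 cells (Homo sapiens) for inhibition, read by MTT assay, with a stated time of 72 h, tested at 10 uM (on this read-out higher numbers stand for more inhibition at the one concentration tested (going by the name of the read-out) and lower numbers for less inhibition), compound 1 gives 18.3%. Compound 2 `CCOC(=O)C1=C(Nc2ccc(F)cc2)S/C(=C\c2ccc[nH]2)C1=O` differs by fluoro in place of hydrogen on an aromatic carbon. In this assay compound 2 returns only a limit of the assay, < 10%, and not a number. The step of a number at least 8.3 percentage points lower from compound 1 to compound 2 (that floor lies within the scatter) is therefore known only as a floor, and that floor sits inside the usual scatter; the reading rests on (the limit of < 10% in this assay, at which 1 of the 2 values shown sits). Compound 2 thus stands at the limit, without a number of its own.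

Compound 3 `CCOC(=O)C1=C(Nc2ccc(C(F)(F)F)cc2)S/C(=C\c2ccc[nH]2)C1=O` is the next step: trifluoromethyl in place of fluoro on an aromatic carbon. Within the data shown here, the one measured step, hydrogen to fluoro on an aromatic carbon, gave no change resolved beyond the scatter, and nothing measured here speaks to a trifluoromethyl group. No step beyond the scatter is therefore expected in this assay. The step expected is a step that the limit leaves unreadable from compound 2 to compound 3. Compound 3 is estimated at 8%, in the range 0% to 20%, most likely again reported only as the limit.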

Compound 3, a percentage reported as inhibition, at one concentration (the size of the read-out at that concentration, not a potency): 19.1%
The estimate for compound 3 lay 11.1 percentage points below the measured number; measured number inside the range.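

Compound 3 is the one substituted compound shown that returns a number rather than a limit in this assay, so a group at this position can now be compared directly with hydrogen. That comparison gives a number 0.8 percentage points higher from compound 1 to compound 3 (within the scatter), and no change between hydrogen and trifluoromethyl at this position is resolved in this assay. The step from fluoro to trifluoromethyl is a number at least 9.1 percentage points higher from compound 2 to compound 3 (that floor lies within the scatter), and it remains a floor rather than a measured size, resting on a limit: the limit of < 10% in this assay, at which 1 of the 3 values shown sits.

Whether compound 2 truly differs from compound 1 or compound 3 cannot be told, as its entry in this assay is a limit and not a number. Also open, on these data alone, is whether any other group at this position, such as an amine, a carboxylic acid or a methoxy group, would move the inhibition beyond the scatter from the level of compound 1.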